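Working notes: bromo to chloro on compound 1

A few compounds are considered here, and "the series" means these few. Any claim that something is new, unique, unknown or untested is made for them only; others in the source may bear on it.

compound 1 `O=c1nc2ccc(Br)cn2cc1Cc1ccc(Br)cc1`: 97200 nM
compound 2 `CC1(C)OC2O[C@@H](Cc3cn4ccccc4nc3=O)C(OCc3ccccc3)C2O1`: > 1000000 nM (a limit of the assay, not a number)

Among the measured compounds shown here, in a functional assay on MCF7 cells (Homo sapiens) for cytotoxicity, read by MTT assay, with a stated time of 24 h (on this read-out lower numbers stand for stronger inhibition and higher numbers for weaker inhibition), compound 1 gives 97200 nM, the only actual number so far. The reading for compound 2 is a limit, so no step can be read from the pair.

Compound 3 `O=c1nc2ccc(Br)cn2cc1Cc1ccc(Cl)cc1` keeps the core of compound 1 and differs at a single place: chloro in place of bromo on an aromatic carbon. This is chloro in place of bromo on an aromatic carbon, para to a large group. For the measured compounds named here, no measured pair shows a change of this kind, so the expectation rests on the structural change alone, and no step beyond the scatter is expected in this assay. The expected change is a 1.1-fold lower number from compound 1 to compound 3 (0.03 log units; within the scatter). For compound 3 the estimated value is 90000 nM, with an expected range of 40000 nM to 200000 nM.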

Compound 3, half-maximal inhibitory concentration: > 1000000 nM
Compound 3: only a limit was reported; the forecaster's own chance of this, stated with the estimate: 10%; at least 11-fold (1.04 log units) between middle value and limit.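

In this assay compound 3 gives > 1000000 nM, which is a limit and not a number. The series now has its first readable step: with chloro in place of bromo on an aromatic carbon, para to a large group, the change is an at least 10-fold higher number from compound 1 to compound 3 (1.01 log units; beyond the scatter), so activity in this assay is sensitive to this single halogen exchange at this position. Only the lower bound of that step can be read, and the reading rests on a shared limit: the limit of > 1000000 nM in this assay, at which 2 of the 3 values shown sit.

Going by these compounds, whether a different group at this position, such as fluoro, methoxy or an amine, would give a measurable number remains open. Also open, on these data alone, is whether the same exchange on the bromo of the shared core would have a comparable effect.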